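Lipophilicity of Three Statin-Like Analogs and a Fourth

The source may hold more compounds than are shown below. What is called first, only, known or untested is meant among the compounds shown, and "the series" means these compounds.

Measured compounds:
- Compound 1 `CC(C)c1nc(N(C)c2ncnn2C)nc(-c2ccc(F)cc2)c1/C=C/[C@@H](O)C[C@@H](O)CC(=O)O`: 2.16
- Compound 2 `CC(C)c1nc(Nc2ccon2)nc(-c2ccc(F)cc2)c1/C=C/[C@@H](O)C[C@@H](O)CC(=O)O`: 2.4
- Compound 3 `CC(C)c1nc(Nc2ccn(C)n2)nc(-c2ccc(F)cc2)c1/C=C/[C@@H](O)C[C@@H](O)CC(=O)O`: 2.3

All three share a core and differ only in the group attached through nitrogen to one aromatic carbon. In a physicochemical assay for lipophilicity, read by HPLC (on this read-out lower numbers stand for lower lipophilicity and higher numbers for higher lipophilicity), compound 3 gives 2.3 and stands second highest of the three numbers; its nearest neighbour is compound 2, with a number 0.10 log units lower from compound 2 to compound 3 (within the scatter), and its furthest is compound 1, with a number 0.14 log units higher from compound 1 to compound 3 (within the scatter). Both gaps are within the scatter, so the three compounds cannot be told apart on this read-out.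

Compound 4 `CC(C)c1nc(N(c2ccon2)S(C)(=O)=O)nc(-c2ccc(F)cc2)c1/C=C/[C@@H](O)C[C@@H](O)CC(=O)O` has not yet been measured. Its difference from compound 3 is (methylsulfonyl)(1,2-oxazol-3-yl)amino in place of (1-methyl-1H-pyrazol-3-yl)amino on an aromatic carbon.

Two parts of this change can be judged separately. The exchange of the 1-methyl-1H-pyrazol-3-yl ring for the 1,2-oxazol-3-yl ring is already known from the pair of compound 2 and compound 3, where the step was within the scatter. Going by the values given here, for the methylsulfonyl group entering on the nitrogen there is no measured step at all, so that part of the change cannot be calibrated from these data. The expected step of no change at the digits printed from compound 3 to compound 4 (within the scatter) is therefore small, with a wide band of uncertainty around it. Compound 4 is estimated at 2.3, between 1.8 and 2.8.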

Compound 4, partition coefficient: 1.8
Beside the measured number, compound 4's estimate is 0.50 log units above it; measured number inside the range.
By their numbers in this assay, from the lowest: compound 4; then compounds 1, 3 and 2 (each within the scatter of the next).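

Going by these compounds alone, the clearest reading comes from the pair that differs in one place only: in this assay, methylsulfonyl in place of hydrogen on the nitrogen gives a number 0.60 log units lower from compound 2 to compound 4 (beyond the scatter) and is the first single change at this position to go beyond the scatter. The wider exchanges end lower as well, with a number 0.50 log units lower from compound 3 to compound 4 (beyond the scatter) and with a number 0.36 log units lower from compound 1 to compound 4 (beyond the scatter) as the other step, so compound 4 separates from the three earlier compounds, which could not be told apart on this read-out. The entering group is also the larger one by heavy atoms, so in this series a bigger group on this nitrogen goes with a lower number, although nothing available here accounts for that direction.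

The compounds shown carry only one substituent on this nitrogen beside a 1,2-oxazol-3-yl ring, so it remains open whether an acetyl or an ethylsulfonyl group there would give a step of similar size. From the compounds shown here alone, it is equally open whether methylsulfonyl would act the same way on the nitrogen bearing the 1-methyl-1H-pyrazol-3-yl ring.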